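Replacing a saturated ring with a sulfonylphenyl group

This account rests on a few compounds, and the source may have more. Where it says the series, first, only, none or still open, it means among the compounds named here.

Compound 1 `Cc1nc(C(=O)O)c(N)c2c1C(=O)N(Cc1ccccc1)C2=O` carries a carboxy group on its aromatic carbon, and in a physicochemical assay for solubility, using the shake flask method, in simulated intestinal fluid, measured as kinetic solubility, with a stated time of 2 h, at 25 degrees C, at pH 6.5 (a higher number here means a more soluble compound, a lower number a less soluble compound), compound 1 gives 177000 nM. Compound 2 `Cc1nnc(-c2nc(C)c3c(c2N)C(=O)N(Cc2ccccc2)C3=O)o1` differs only in the 5-methyl-1,3,4-oxadiazol-2-yl in place of carboxy, and for compound 2 this assay reports only a limit, < 5000 nM (the limit of < 5000 nM in this assay, at which 1 of the 3 values shown sits). That step is an at least 35-fold lower number from compound 1 to compound 2 (1.54 log units; beyond the scatter). Compound 3 `Cc1noc(-c2nc(C)c3c(c2N)C(=O)N(CC2CCOCC2)C3=O)n1` gives 5700 nM in this assay, the lowest of the two numbers shown, and its gap to compound 1 is beyond the usual scatter.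

Compound 4 `Cc1noc(-c2nc(C)c3c(c2N)C(=O)N(Cc2ccc(S(C)(=O)=O)cc2)C3=O)n1` differs from compound 3 in one place: 4-(methylsulfonyl)phenyl in place of oxan-4-yl on a saturated chain carbon bound to an amide-type nitrogen in a ring. Going by the values given here, no measured step changes the group on this saturated chain carbon; the single measured step concerns the aromatic carbon instead, so it offers no direct guide here. Among the compounds with values here, with no comparable step to lean on, the expectation for compound 4 is a number close to compound 3, within the scatter, and the expected step is a 1.4-fold lower number from compound 3 to compound 4 (0.15 log units; within the scatter). Compound 4 is therefore estimated at 4000 nM, with a range from 1000 nM to 15000 nM.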

Compound 4, solubility: < 5000 nM
Compound 4 ended at the assay's limit (the forecaster's own chance of this, stated with the estimate: 40%); the middle value does not contradict the limit.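

Going by these compounds alone, this is the first measured step at the saturated chain carbon bound to an amide-type nitrogen in a ring, and swapping oxan-4-yl for 4-(methylsulfonyl)phenyl there gives an at least 1.1-fold lower number from compound 3 to compound 4 (0.05 log units; that floor lies within the scatter). In this assay compound 4 gives < 5000 nM, which is a limit of the assay and not a number. The step is therefore only a floor, and the larger ring group with its extra hydrogen-bond acceptor cannot be told apart from oxan-4-yl here, as the reading sits where the assay stops giving numbers: the limit of < 5000 nM in this assay, at which 2 of the 4 values shown sit.

Going by these compounds, how far compound 4 truly lies past its limit stays open, and with it the real size of this change. Also open, on these data alone, is how this assay would read with an amine in place of the 4-(methylsulfonyl)phenyl group on this same carbon.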